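From benzyl to 4-chlorophenoxy: what one step suggests

A few compounds are considered here, and "the series" means these few. Any claim that something is new, unique, unknown or untested is made for them only; others in the source may bear on it.

Going by the values given here, in a functional assay on the whole organism with Mus musculus as the target, in the formalin test (on this read-out lower numbers stand for an effect already at smaller amounts and higher numbers for an effect only at larger amounts of compound), compound 2 `O=C(Nc1ccc2[nH]c(O)nc2c1)C(=O)N1CCC(Cc2ccccc2)CC1` gives 14 mg/kg, the only exact number so far. Compound 1 `O=C(Nc1ccc2[nH]c(O)nc2c1)C(=O)N1CCC(Cc2ccc(F)cc2)CC1` is reported only as a limit, > 20 mg/kg. Among the compounds with values here, the one measured step is hydrogen in place of fluoro on an aromatic carbon: an at least 1.4-fold lower number from compound 1 to compound 2 (0.15 log units; that floor lies within the scatter).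

Compound 3 `O=C(Nc1ccc2[nH]c(O)nc2c1)C(=O)N1CCC(Oc2ccc(Cl)cc2)CC1` has not yet been measured. Its difference from compound 2 is 4-chlorophenoxy in place of benzyl on a saturated ring carbon. Within the data shown here, no measured step covers an exchange of this whole group, so the guide here is only partial. Compound 3 does hold a halogen atom again, as compound 1 does, and that makes the fluoro step the nearest comparison. On the strength of an at least 1.4-fold lower number from compound 1 to compound 2 (0.15 log units; that floor lies within the scatter), no shift beyond the scatter is expected in this assay, with only a slight lean towards higher numbers. The expected change is a 1.3-fold higher number from compound 2 to compound 3 (0.11 log units; within the scatter). For compound 3 the estimate is 18 mg/kg, with an expected range of 7 mg/kg to 50 mg/kg.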

Compound 3, dose for half-maximal effect: 14 mg/kg
Beside the measured number, compound 3's estimate is 1.3-fold (0.11 log units) above it; the measured number falls inside the stated range.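

In this assay, exchanging the whole benzyl group for 4-chlorophenoxy on a saturated ring carbon gives no change at the digits printed from compound 2 to compound 3 (within the scatter), so this position tolerates a change of a complete group, not just of one atom, without a shift beyond the scatter. This exchange brings in both an oxygen and a chlorine, and the earlier fluoro step gave no sign of how such a change would turn out. Compound 3 also carries a halogen and still has an exact number, and the comparison with the other halogen-bearing compound gives an at least 1.4-fold lower number from compound 1 to compound 3 (0.15 log units; that floor lies within the scatter), where only a floor can be read, as compound 1 is reported as a limit and not as a number: the limit of > 20 mg/kg in this assay, at which 1 of the 3 values shown sits.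

The oxygen and the chlorine enter together, so the compounds shown cannot separate what each contributes, and a plain phenoxy group or a 4-chlorobenzyl group would be needed to tell them apart. Also open, as far as these compounds go, is how the read-out responds at this saturated ring carbon to a group of a different kind, such as an amine, a carboxylic acid or a longer chain in place of benzyl.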